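Hydroxyphenyl positional series, topoisomerase inhibition notes

This account rests on a few compounds, and the source may have more. Where it says the series, first, only, none or still open, it means among the compounds named here.

In an assay on isolated protein for inhibition of DNA topoisomerase 1 (Homo sapiens), with a stated time of 30 min, tested at 100 uM (a higher number here means more inhibition at the concentration tested (going by the name of the read-out), a lower number less inhibition), compound 1 `Oc1cccc(-c2cc(-c3ccccc3O)nc(-c3ccccc3O)c2)c1` gives 4.9%, compound 2 `Oc1cccc(-c2cc(-c3cccc(O)c3)nc(-c3ccccc3O)c2)c1` gives 1.9% and compound 3 `Oc1ccc(-c2cc(-c3cccc(O)c3)cc(-c3ccc(O)cc3)n2)cc1` gives 0%. Compound 2 stands second highest of the three numbers, and both its neighbours, compound 1 and compound 3, lie within the scatter of it. Compound 4 `Oc1cccc(-c2cc(-c3cccc(O)c3)nc(-c3cccc(O)c3)c2)c1` has not been measured. It differs from compound 2 as follows: 3-hydroxyphenyl in place of 2-hydroxyphenyl on an aromatic carbon. Among the compounds with values here, the only measured step of the same kind, a number 3 percentage points lower from compound 1 to compound 2 (within the scatter), stayed within the scatter, so no step beyond the scatter is expected here either. For compound 4 the expected step is a number 0.4 percentage points lower from compound 2 to compound 4 (within the scatter). Compound 4 is therefore estimated at 1.5%, with a range from 0% to 8% in this assay.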

Compound 4, a percentage reported as inhibition, at one concentration (the size of the read-out at that concentration, not a potency): 0%
Compound 4: middle estimate off by 1.5 percentage points, on the high side, within the range that was stated.
By their numbers in this assay, from the lowest: compounds 3, 4, 2 and 1 (each within the scatter of the next).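

Replacing the last 2-hydroxyphenyl, next to the ring nitrogen, with 3-hydroxyphenyl gives a number 1.9 percentage points lower from compound 2 to compound 4 (within the scatter) in this assay. The same change therefore stays within the scatter a second time, now in a compound already carrying two 3-hydroxyphenyl groups, as it did for a number 3 percentage points lower from compound 1 to compound 2 (within the scatter). Across these three compounds, the place of the hydroxyl on this ring does not separate the numbers, and nothing available explains this.

Still open, from the compounds shown here alone, is whether an amine or a carboxylic acid in place of the hydroxyl at this position would give a step beyond the scatter.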